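The source may report more compounds than this note shows. Statements on the series, on what has been measured and on what is new or still open speak of the compounds shown alone.

Going by the values given here, compound 1 `O=C(Nc1cccnc1)c1ccccc1` is the reference point of the series so far: in an assay on V79 cells for inhibition of cytochrome P450 11B2, mitochondrial (Homo sapiens), tested at 500 nM (on this read-out higher numbers stand for more inhibition at the one concentration tested (going by the name of the read-out) and lower numbers for less inhibition), compound 1 gives 30%, while compound 2 `Cc1ccc(C(=O)Nc2cccnc2)cc1` gives 25%, a difference of a number 5 percentage points lower from compound 1 to compound 2 (within the scatter). Compound 3 `O=C(Nc1cccnc1)c1cccc(Cl)c1` differs from compound 1 by chloro in place of hydrogen on an aromatic carbon. Among the compounds with values here, the only measured step that bears on this, another substituent entering on an aromatic carbon, is a number 5 percentage points lower from compound 1 to compound 2 (within the scatter) and stays within the scatter. For compound 3 the expectation is therefore no step beyond the scatter in this assay, no change at the digits printed from compound 1 to compound 3 (within the scatter). Compound 3 is thus estimated at 30%, within 15% to 45%.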

Compound 3, a percentage reported as inhibition, at one concentration (the size of the read-out at that concentration, not a potency): 26%
For compound 3 the middle estimate is 4 percentage points above the measured one; measured number inside the range.
By their numbers in this assay, from the lowest: compounds 2, 3 and 1 (each within the scatter of the next).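

At the aromatic carbon meta to a group of 9 heavy atoms, chloro in place of hydrogen gives a number 4 percentage points lower from compound 1 to compound 3 (within the scatter) in this assay and so adds a second step within the scatter. A single chlorine at this position therefore leaves the read-out as close to compound 1 as the methyl of compound 2 does. Nothing available explains this result.

Going by these compounds, whether an amine, a carboxylic acid or a longer chain at this carbon would give a step beyond the scatter remains open. Also open, on these data alone, is how chloro would behave on the other carbons of that ring.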